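Larger Group on the Same Aromatic Carbon, Cytotoxicity Expected

The source may hold more compounds than are shown below. What is called first, only, known or untested is meant among the compounds shown, and "the series" means these compounds.

Compound 3 `O=C(NC(=O)c1ccccc1O)c1ccc(F)cc1` shares its core with compound 1 `Cc1ccc(C(=O)NC(=O)c2ccccc2O)cc1` and compound 2 `CC(C)(C)c1ccc(C(=O)NC(=O)c2ccccc2O)cc1`; the three differ only in the group carried on one aromatic carbon. In an ADME assay on L6 cells (Rattus norvegicus) for cytotoxicity, read by resazurin assay, with a stated time of 72 h (on this read-out lower numbers stand for stronger inhibition and higher numbers for weaker inhibition), compound 3 gives 38 ug/mL, the second highest of the three numbers. Compound 1 gives 46 ug/mL, and the two values lie within the scatter of each other: a 1.2-fold lower number from compound 1 to compound 3 (0.08 log units; within the scatter). Compound 2 gives 2.3 ug/mL, far apart from compound 3: a 17-fold higher number from compound 2 to compound 3 (1.22 log units; beyond the scatter).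

Compound 4 `O=C(NC(=O)c1ccccc1O)c1ccc(OCc2ccccc2)cc1` is compound 3 with one change, (benzyloxy in place of fluoro on an aromatic carbon). The measured step that bears on it is the exchange of a small group for a bulkier one on the same carbon: a 20-fold lower number from compound 1 to compound 2 (1.30 log units; beyond the scatter), a large step toward a lower number, while the exchange of two small groups, a 1.2-fold lower number from compound 1 to compound 3 (0.08 log units; within the scatter), stayed within the scatter. Benzyloxy is the bulkiest group to enter this position so far, so a large step to a lower number is expected, of roughly the size seen with tert-butyl: a 7.6-fold lower number from compound 3 to compound 4 (0.88 log units; beyond the scatter). Compound 4 is therefore estimated at 5 ug/mL, with a range from 1.5 ug/mL to 20 ug/mL. Among the measured compounds shown here, only one bulky group has been measured, so this expectation rests on a single step.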

Compound 4, half-maximal inhibitory concentration: 64 ug/mL
Compound 4: the middle estimate sits 13-fold (1.11 log units) below what was measured; measured number outside the range, above it.
By their numbers in this assay, from the lowest: compound 2; then compounds 3, 1 and 4 (each within the scatter of the next).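

In this assay, putting benzyloxy, with its 8 heavy atoms and an aromatic ring, in place of the single fluorine atom does not separate the two compounds: a 1.7-fold higher number from compound 3 to compound 4 (0.23 log units; within the scatter). The same holds when benzyloxy replaces methyl, a 1.4-fold higher number from compound 1 to compound 4 (0.14 log units; within the scatter), so on this aromatic carbon the number of heavy atoms in a group does not by itself set the reading, and compound 2 with tert-butyl now stands apart from the other three, including a 28-fold higher number from compound 2 to compound 4 (1.44 log units; beyond the scatter). Nothing available here accounts for the gap between tert-butyl and benzyloxy on this carbon.

The compounds shown leave open whether the low number belongs to tert-butyl alone or is shared by related carbon groups such as isopropyl or cyclohexyl. They also leave open how this cytotoxicity reading would respond to an amine or a carboxylic acid on the same carbon, or to a longer chain ending in a benzene ring.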